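Methoxycarbonyl to carbamoyl on the shared core

The compounds below may be only part of what the source reports. "The series", "measured", "known", "first", "only" and "open" are said of these compounds alone.

Among the measured compounds shown here, in an ADME assay (liver) for metabolic stability, with Liver microsome (Homo sapiens) as the target, read by LC-MS, using microsomes, with NADPH named in the record, with a stated time of 1 h, tested at 1 uM, in the absence of a further agent (on this read-out lower numbers stand for a less stable compound and higher numbers for a more stable compound), compound 2 (`COC(=O)c1cnc(Oc2ccc3c(c2)B(O)OC3)cn1`) gives 0% as the only number so far. Compound 1 (`O=C(O)c1cnc(Oc2ccc3c(c2)B(O)OC3)cn1`) stands at "not determined" (no result reported) and offers no comparison. Compound 3 (`NC(=O)c1cnc(Oc2ccc3c(c2)B(O)OC3)cn1`) carries amino in place of methoxy on a carbonyl carbon. For the measured compounds named here, no measured step guides the size of this change. Compound 2 at 0% leaves no room for a fall on this read-out. An upward a number 60 percentage points higher from compound 2 to compound 3 (beyond the scatter) is expected in this assay and would lie beyond the scatter. Compound 3 is estimated at 60% with an expected range of 25% to 92% for the coming measurement.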

Compound 3, percent of the compound remaining: 100%
For compound 3 the middle estimate is 40 percentage points below the measured one; the whole stated range lies below it.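

Amino in place of methoxy on a carbonyl carbon gives a number 100 percentage points higher from compound 2 to compound 3 (beyond the scatter) in this assay. Among the compounds shown here, this is the first readable step, and it shows that a change at this one place on the shared core can carry the read-out across its whole span. Nothing at hand gives a reason for the step.

Open, on these data alone, is whether the gain stays with a larger group on the same carbonyl carbon, such as methylamino or dimethylamino. Ethoxy in place of methoxy would show how far the ester result extends.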